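From 4-chlorophenyl to 3-chlorophenyl: working notes on the series

The source may report more compounds than this note shows. Statements on the series, on what has been measured and on what is new or still open speak of the compounds shown alone.

Compound 1 `C#CCOc1ccc2c(=O)c(-c3cc(OC)c(OC)cc3OC)coc2c1`: > 10000 nM (a limit of the assay)
Compound 2 `COc1cc(OC)c(-c2coc3cc(OCc4ccc(Cl)cc4)ccc3c2=O)cc1OC`: 4400 nM

Among the compounds with values here, in a functional assay on HUVEC cells (Homo sapiens) for antiproliferative activity, read by MTT assay, with a stated time of 24 h (a lower number here means a stronger inhibitor, a higher number a weaker inhibitor), compound 2 gives 4400 nM, the only actual number so far. For compound 1 the reading is the limit of > 10000 nM in this assay, at which 1 of the 2 values shown sits. Compound 3 `COc1cc(OC)c(-c2coc3cc(OCc4cccc(Cl)c4)ccc3c2=O)cc1OC` differs from compound 2 as follows: 3-chlorophenyl in place of 4-chlorophenyl on a saturated chain carbon bound to an oxygen on an aromatic ring. Within the data shown here, the one measured step, an at least 2.2-fold lower number from compound 1 to compound 2 (0.35 log units; beyond the scatter), replaces ethynyl rather than exchanging one chlorophenyl for another, so it offers no direct size for this change. No step beyond the scatter is therefore expected, and no direction is favoured. The estimated step is no change at the digits printed from compound 2 to compound 3 (within the scatter). For compound 3 the expected value is 4400 nM, with an estimated range of 1800 nM to 10000 nM.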

Compound 3, half-maximal inhibitory concentration: > 10000 nM
Compound 3: a limit, no number (the forecaster's own chance of this, stated with the estimate: 15%); at least 2.2-fold (0.35 log units) between middle value and limit.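

In this assay, 3-chlorophenyl in place of 4-chlorophenyl on a saturated chain carbon bound to an oxygen on an aromatic ring gives an at least 2.2-fold higher number from compound 2 to compound 3 (0.35 log units; beyond the scatter), so these two chlorophenyl groups are not interchangeable here, although their atom counts are identical. Compound 3 gives a limit, not a number, and that reading is shared with compound 1: the limit of > 10000 nM in this assay, at which 2 of the 3 values shown sit. The step between compound 1 and compound 3 cannot be read.

From the compounds shown here alone, the full size of the step to compound 3 remains open. Also open, going by these compounds, is how an amine or a carboxylic acid in place of the chlorine would read.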